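The source may hold more compounds than are shown below. What is called first, only, known or untested is meant among the compounds shown, and "the series" means these compounds.

Measured in a functional assay on HT-29 cells (Homo sapiens) for cytotoxicity, read by sulforhodamine B assay, with a stated time of 48 h; a higher number here means a weaker inhibitor of growth, a lower number a stronger inhibitor of growth:

- Compound 1 `CCOC(=O)c1[nH]c2ccc(OC)cc2c1C(=O)c1cc(OC)c(OC)c(OC)c1N` gives 5150 nM
- Compound 2 `COc1cc(Cc2c[nH]c3ccccc23)c(N)c(OC)c1OC` gives > 100000 nM
- Compound 3 `COc1cc(Cc2c[nH]c3ccc(Cl)cc23)c(N)c(OC)c1OC` gives "not active" (no number reported)

Compound 3 has no single number and is reported only as "not active" (no number reported). Compound 2 gives > 100000 nM, which is a limit of the assay and not a number. Of the three, only compound 1 has a measured number, 5150 nM.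

Compound 4 `COc1cc(Cc2c[nH]c3ccc(C)cc23)c(N)c(OC)c1OC` has not yet been measured. The change that leads to it is methyl in place of chloro on an aromatic carbon, with methyl in place of chloro on an aromatic carbon. Within the data shown here, no pair of measured compounds shows this change, so the step in this assay can only be estimated. Little or no step beyond the usual scatter is expected, and the expectation is that the new compound stays a very weak inhibitor of growth, as compound 3 does with its report of "not active" (no number reported). A report without a usable number is also quite possible. For compound 4 the estimated value is 80000 nM, with an expected range from 15000 nM to 150000 nM.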

Compound 4, concentration for 50% growth inhibition: "not active" (no number reported)
For compound 4 the study gives words and no number, so the estimate cannot be set against anything.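

In this assay, among these compounds, compound 3 and compound 4 are both reported as not active, with no number, so no step from chloro to methyl can be read between them. The compounds shown leave open where these two stand relative to the one limit reported: the limit of > 100000 nM in this assay, at which 1 of the 4 values shown sits.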